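The compounds below may be only part of what the source reports. "The series", "measured", "known", "first", "only" and "open" are said of these compounds alone.

Measured compounds:
compound 1 `Cc1nn(CC2(O)COC2)cc1Nc1nc(N)c2c(C#N)c(N3CCC[C@H]3C)n(C)c2n1` — 57 nM
compound 2 `CN(C)c1c(C#N)c2c(N)ncnc2n1C` — 4620 nM

In an assay on isolated protein for inhibition of Leucine-rich repeat serine/threonine-protein kinase 2 (Homo sapiens), read by TR-FRET and LanthaScreen, with stated times of 50 min and 30 min, in the presence of a further agent that is not named here (a lower number here means a stronger inhibitor, a higher number a weaker inhibitor), compound 1 gives 57 nM, the lowest of the two numbers. Going by the values given here, only part of that core is shared by compound 2, and in this assay compound 2 gives 4620 nM, a gap far beyond the usual scatter; with only two compounds measured, no single change between them is set out, so the pair shows just how much the larger compound adds.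

Compound 3 `Cc1n[nH]cc1Nc1nc(N)c2c(C#N)c(N3CCC[C@H]3C)n(C)c2n1` has not yet been measured. It differs from compound 1 in one place: hydrogen in place of (3-hydroxyoxetan-3-yl)methyl on an aromatic nitrogen. Among the compounds with values here, the only structural difference here is the loss of the (3-hydroxyoxetan-3-yl)methyl group from the aromatic nitrogen, and no measured pair shows what that costs. The step from compound 1 to compound 3 in this assay is expected to be a modest loss, a 2.6-fold higher number from compound 1 to compound 3 (0.42 log units; beyond the scatter), since the rest of the molecule that makes compound 1 so much stronger than compound 2 is kept. Compound 3 is estimated at 150 nM, within 50 nM to 500 nM.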

Compound 3, half-maximal inhibitory concentration: 42 nM
Compound 3: middle estimate off by 3.6-fold (0.55 log units), on the high side, outside the stated range (below it).
By their numbers in this assay, from the lowest: compounds 3 and 1 (each within the scatter of the next); then compound 2.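

Taking the (3-hydroxyoxetan-3-yl)methyl group off the aromatic nitrogen and leaving a hydrogen there gives a 1.4-fold lower number from compound 1 to compound 3 (0.13 log units; within the scatter) in this assay, so the two compounds cannot be told apart. At this position, then, the group with its four-membered ring is not required for a value of this size, and the unsubstituted nitrogen serves equally well in this read-out. Nothing available here accounts for this result.

From the compounds shown here alone, whether other groups on that nitrogen, such as a methyl, a longer chain ending in an amine, or a carboxylic acid, would also stay within the scatter of compound 3 remains open. The compounds shown speak to this one assay alone, so how compound 1 and compound 3 compare in any other setting also stays open.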